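The source may report more compounds than this note shows. Statements on the series, on what has been measured and on what is new or still open speak of the compounds shown alone.

Compounds measured so far:
- compound 1 `O=C(c1cc(Oc2cccc(NC(=S)Nc3ccc(F)c(F)c3)c2)ccn1)N1CCCC1`: 52000 nM
- compound 2 `CCNC(=O)c1cc(Oc2cccc(NC(=S)Nc3cccc(C(F)(F)F)c3)c2)ccn1`: 19400 nM
- compound 3 `O=C(NC1CCCCC1)c1cc(Oc2cccc(NC(=S)Nc3cccc(C(F)(F)F)c3)c2)ccn1`: 8400 nM

All three numbers come from a functional assay on HCT-116 cells (Homo sapiens) for cytotoxicity, read by MTT assay, with a stated time of 48 h; a higher number here means a weaker inhibitor, a lower number a stronger inhibitor. Compound 3 gives the lowest number of the three; compound 2 stands nearest, and compound 1 furthest away. Going by the values given here, the one step that can be isolated, a 2.3-fold lower number from compound 2 to compound 3 (0.36 log units; beyond the scatter), replaces ethyl with cyclohexyl on the amide-type nitrogen and lowers the number beyond the scatter.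

Compound 4 `O=C(c1cc(Oc2cccc(NC(=S)Nc3cccc(C(F)(F)F)c3)c2)ccn1)N1CCCC1` differs from compound 3 in one place: pyrrolidin-1-yl in place of cyclohexylamino on a carbonyl carbon. Among the compounds with values here, no measured pair shows exactly this change. The only bearing comes from the amide-nitrogen step just named, which shows that a larger group on that nitrogen lowered the number, and from the bare fact that compound 1, the only pyrrolidinyl amide measured, gives the highest number of the set, though it also carries a different thiourea aryl group, so its two values with compound 3 cannot be read as a clean step.

On that basis compound 4 is expected to give a higher number than compound 3, a step of roughly a 3.0-fold higher number from compound 3 to compound 4 (0.47 log units; beyond the scatter). The estimate for compound 4 in this assay is 25000 nM, with a plausible range from 9000 nM to 60000 nM.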

Compound 4, half-maximal inhibitory concentration: 19200 nM
Compound 4: middle estimate off by 1.3-fold (0.11 log units), on the high side; the range from low to high includes it.
By their numbers in this assay, from the lowest: compound 3; then compounds 4 and 2 (each within the scatter of the next); then compound 1.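

In this assay, a 2.3-fold higher number from compound 3 to compound 4 (0.36 log units; beyond the scatter) and a 1.0-fold lower number from compound 2 to compound 4 (0.00 log units; within the scatter) show that, of the three groups seen on this carbonyl carbon, cyclohexylamino alone separates from the others, while pyrrolidin-1-yl and ethylamino cannot be told apart. Going by these compounds alone, compound 4 also gives the first clean reading of the aryl group on the amide-type nitrogen: with pyrrolidin-1-yl held constant, a 2.7-fold lower number from compound 1 to compound 4 (0.43 log units; beyond the scatter) accompanies 3-(trifluoromethyl)phenyl in place of 3,4-difluorophenyl. No available evidence accounts for either difference.

The compounds shown leave open whether the lower number of compound 3 follows the amide hydrogen or the six-membered carbon ring, a question that piperidin-1-yl or cyclopentylamino on the same carbonyl carbon could help separate. They also leave open whether the aryl step holds with cyclohexylamino in place of pyrrolidin-1-yl.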